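The source may hold more compounds than are shown below. What is called first, only, known or untested is meant among the compounds shown, and "the series" means these compounds.

In a functional assay on MGC-803 cells (Homo sapiens) for inhibition, read by MTT assay, with a stated time of 48 h (a lower number here means a stronger inhibitor, a higher number a weaker inhibitor), compound 1 `CCC/C=C/C(=O)N(Cc1ccc(OC)c(O)c1)c1cc(OC)c(OC)c(OC)c1` gives 70 nM and compound 2 `COc1ccc(CN(C(=O)CCCCCl)c2cc(OC)c(OC)c(OC)c2)cc1O` gives 540 nM, the higher of the two numbers. Compound 3 `COc1ccc(CN(C(=O)CBr)c2cc(OC)c(OC)c(OC)c2)cc1O` has not yet been measured. It departs from compound 2 in the acyl chain: bromo in place of 3-chloropropyl on a saturated chain carbon bound to a carbonyl carbon, with bromo in place of 3-chloropropyl on a saturated chain carbon bound to a carbonyl carbon. Among the compounds with values here, only one measured step bears on this change, a 7.7-fold higher number from compound 1 to compound 2 (0.89 log units; beyond the scatter), which puts 4-chlorobutyl in place of pent-1-en-1-yl on a carbonyl carbon and lies beyond the scatter. That single step shows that the group on this carbonyl carbon can move the number, but it does not settle the direction for the new group. A step no larger than that one is expected, leaning slightly towards a lower number. The expected change is a 1.8-fold lower number from compound 2 to compound 3 (0.26 log units; within the scatter). For compound 3 the estimated value is 300 nM, with an expected range of 60 nM to 1500 nM.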

Compound 3, half-maximal inhibitory concentration: 140 nM
Compound 3: the middle estimate sits 2.1-fold (0.33 log units) above what was measured, and the stated range covers the measured number.
By their numbers in this assay, from the lowest: compounds 1 and 3 (each within the scatter of the next); then compound 2.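

In this assay, bromo in place of 3-chloropropyl on a saturated chain carbon bound to a carbonyl carbon gives a 3.9-fold lower number from compound 2 to compound 3 (0.59 log units; beyond the scatter) and this step lies beyond the scatter, so the acyl chain can move the number downwards as well as upwards. Bromomethyl in place of pent-1-en-1-yl on a carbonyl carbon gives a 2.0-fold higher number from compound 1 to compound 3 (0.30 log units; within the scatter) and stays within the scatter, so these two quite different groups on the carbonyl carbon cannot be told apart in this assay, while 4-chlorobutyl stands apart from both. Nothing shown here gives a reason for these steps.

The halogen and the chain length change together from compound 2 to compound 3, so the compounds shown leave open which of the two carries the step. Also open, on these data alone, is how a chloromethyl group, a 4-bromobutyl group or an amine on a longer chain would stand on this carbonyl carbon.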